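Swapping the amide tail of compound 1 for a triazolylethyl

The compounds below may be only part of what the source reports. "The series", "measured", "known", "first", "only" and "open" are said of these compounds alone.

Of the compounds shown here, three that share one core have been measured in an ADME assay on MDCK-MDR1 cells (Canis lupus familiaris) for permeability, in the apical to basolateral direction, with a stated time of 180 min; a higher number here means that the compound crosses the layer faster, a lower number that the compound crosses the layer more slowly. Compound 1, `CN(C)CCC(=O)Nc1ccc([C@H]2[C@@H](F)[C@@H](F)C[C@@H](F)[C@H]2F)cc1`, gives 3.7 10^-6 cm/s, the lowest of the three numbers. Compound 2, `O=C(c1ccc([C@H]2[C@@H](F)[C@@H](F)C[C@@H](F)[C@H]2F)cc1)N1CC(O)C1`, gives 6.7 10^-6 cm/s in this assay, and compound 3, `CN(CCC#N)C(=O)c1ccc([C@H]2[C@@H](F)[C@@H](F)C[C@@H](F)[C@H]2F)cc1`, gives 8.1 10^-6 cm/s. The steps between them are small: a 1.8-fold higher number from compound 1 to compound 2 (0.26 log units; within the scatter), a 2.2-fold higher number from compound 1 to compound 3 (0.34 log units; beyond the scatter) and a 1.2-fold higher number from compound 2 to compound 3 (0.08 log units; within the scatter).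

Compound 4, `CC(C(=O)Nc1ccc([C@H]2[C@@H](F)[C@@H](F)C[C@@H](F)[C@H]2F)cc1)n1cncn1`, has not yet been measured. Relative to compound 1 it differs in one place: 1-(1H-1,2,4-triazol-1-yl)ethyl in place of 2-(dimethylamino)ethyl on a carbonyl carbon. The amide-type nitrogen and the carbonyl carbon stay in place, and only the group on that carbonyl carbon changes, whereas both measured steps from compound 1 exchanged the whole side group, not just the part on the carbonyl carbon. They bear on the question only loosely. Both pointed upward from compound 1, one within the scatter and one just beyond it, so a small rise, or no change beyond the scatter, is the most that can be read from them.

For compound 4 the expected value in this assay is therefore 6 10^-6 cm/s, with a range from 3 10^-6 cm/s to 12 10^-6 cm/s. This estimate amounts to a 1.6-fold higher number from compound 1 to compound 4 (0.21 log units; within the scatter).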

Compound 4, apparent permeability: 5.5 10^-6 cm/s
Estimate against measurement, compound 4: 1.1-fold (0.04 log units) above; measured number inside the range.
By their numbers in this assay, from the lowest: compounds 1, 4, 2 and 3 (each within the scatter of the next, the first and the last beyond it).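

Among the compounds shown here, compound 4 is the first compound here in which the amide-type nitrogen stays and only the group on the carbonyl carbon changes, so it isolates this position in a way the whole-side-group exchanges in compound 2 and compound 3 could not. In this assay, replacing 2-(dimethylamino)ethyl with 1-(1H-1,2,4-triazol-1-yl)ethyl gives a 1.5-fold higher number from compound 1 to compound 4 (0.17 log units; within the scatter), which shows that this position can take a larger group with a five-membered aromatic ring, more heavy atoms and more hydrogen-bond acceptors without a step beyond the scatter. No measurement shown here accounts for the size of this step.

This single swap removes the dimethylamino group and brings in the triazole together, so the compounds shown cannot separate what each part contributes to the read-out. A plain ethyl group or a carboxylic acid on the same carbonyl carbon would help to separate them and to test whether a group of a very different kind gives a step beyond the scatter from compound 1.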